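Bromo on the core of compound 1

This account rests on a few compounds, and the source may have more. Where it says the series, first, only, none or still open, it means among the compounds named here.

Values in an ADME assay on J774 cells (Mus musculus) for cytotoxicity; a higher number here means that more compound is needed for the effect, a lower number that less compound is needed:
- compound 1 `COC(=O)c1c[nH]c2cc(OCCOc3ccccc3)ccc2c1=O`: > 20000 nM
- compound 2 `COC(=O)c1c[nH]c2cc(OCc3ccccc3)ccc2c1=O`: 18900 nM
- compound 3 `COC(=O)c1c[nH]c2cc(OCCOc3ccccc3)c(Br)cc2c1=O`: not yet measured

Compound 1 gives only a limit, > 20000 nM, and not a number. Compound 3 carries bromo in place of hydrogen on an aromatic carbon of the shared core (bromo in place of hydrogen on an aromatic carbon). Among the measured compounds shown here, the one measured step, an at least 1.0-fold lower number from compound 1 to compound 2 (0.02 log units; that floor lies within the scatter), changes the chain and not the core, so it bears only weakly on this change. No step beyond the scatter is therefore expected in this assay, in either direction. The expected step is an at least 1.1-fold lower number from compound 1 to compound 3 (0.04 log units; that floor lies within the scatter). For compound 3 the estimate is 18000 nM, with an expected range of 7000 nM to 40000 nM.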

Compound 3, half-maximal effective concentration: > 20000 nM
Compound 3: only a limit was reported; the forecaster's own chance of this, stated with the estimate: 60%; middle value at least 1.1-fold (0.04 log units) from the limit.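

No step from compound 1 to compound 3 can be read in this assay, because both results are limits and not numbers: the limit of > 20000 nM in this assay, at which 2 of the 3 values shown sit.

The compounds shown leave open whether bromo in place of hydrogen on the shared core shifts the number in this assay at all.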